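The source may hold more compounds than are shown below. What is called first, only, known or untested is meant among the compounds shown, and "the series" means these compounds.

Compound 1 `CCCCc1cn(C(c2ccccc2)c2cc3cc(Br)ccc3nc2OC)nn1`: 5.54%
Compound 2 `CCCc1cn(C(c2ccccc2)c2cc3cc(Br)ccc3nc2OC)nn1`: 8.3%
Compound 3 `COc1nc2ccc(Br)cc2cc1C(c1ccccc1)n1cc(-c2ccccc2C(F)(F)F)nn1`: 17.4%

Of the compounds shown here, three with a shared core have so far been tested in an ADME assay on PC-3 cells (Homo sapiens) for cytotoxicity, read by sulforhodamine B assay, with a stated time of 48 h, tested at 10 uM; on this read-out lower numbers stand for less inhibition and higher numbers for more inhibition at the one concentration tested (going by the name of the read-out). Compound 1 stands lowest of the three numbers. Its nearest neighbour is compound 2, where the step is a number 2.8 percentage points higher from compound 1 to compound 2 (within the scatter); the furthest is compound 3, where the step is a number 11.9 percentage points higher from compound 1 to compound 3 (beyond the scatter).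

Compound 4 `COc1nc2ccc(Br)cc2cc1C(c1ccccc1)n1cc(-c2ccc(F)cc2)nn1` has not yet been measured. It differs from compound 1 in a single place: 4-fluorophenyl in place of butyl on an aromatic carbon.

Among the compounds with values here, the step that bears most on this change is the one from compound 1 to compound 3, which also swaps the butyl chain for an aromatic ring and gave a number 11.9 percentage points higher from compound 1 to compound 3 (beyond the scatter). The related step from compound 2 to compound 3, a number 9.1 percentage points higher from compound 2 to compound 3 (within the scatter), stayed within the scatter. A modest rise is therefore expected, though it may not clear the scatter. Compound 4 is expected to give 14% in this assay, most likely between 4% and 26%. This estimate means an expected step of a number 8.5 percentage points higher from compound 1 to compound 4 (within the scatter).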

Compound 4, a percentage reported as inhibition, at one concentration (the size of the read-out at that concentration, not a potency): 16.4%
Estimate against measurement, compound 4: 2.4 percentage points below; the measured number falls inside the stated range.
By their numbers in this assay, from the lowest: compounds 1, 2, 4 and 3 (each within the scatter of the next, the first and the last beyond it).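

In this assay the 4-fluorophenyl group shows a number 10.9 percentage points higher from compound 1 to compound 4 (beyond the scatter), so on this aromatic carbon of the five-membered ring the rise over butyl is not limited to the 2-(trifluoromethyl)phenyl group of compound 3. The comparison with the shorter chain gives a number 8.1 percentage points higher from compound 2 to compound 4 (within the scatter), and exchanging one substituted phenyl group for the other gives a number 1 percentage points lower from compound 3 to compound 4 (within the scatter), so these two aromatic groups cannot be told apart here and only the butyl comparison clears the scatter. Nothing available explains why these groups differ from the butyl chain.

Going by these compounds, it remains open whether an unsubstituted phenyl, a longer chain or a ring carrying an amine would give a similar number at this position. On these data alone, it is also open whether any group here could raise the number much further.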